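Aryl swap on the triazole nitrogen: compound 2 toward compound 3

A few compounds are considered here, and "the series" means these few. Any claim that something is new, unique, unknown or untested is made for them only; others in the source may bear on it.

Of the compounds shown here, two have been measured in a functional assay on A549 cells (Homo sapiens) for antiproliferative activity, read by MTT assay, with a stated time of 48 h; on this read-out lower numbers stand for stronger inhibition and higher numbers for weaker inhibition. Compound 1 `Cc1cccc(-n2nncc2CN2C(=O)C3(C(C#N)=C(N)Oc4c3c3nc5ccccc5nc3c3ccccc43)c3ccccc32)c1` gives 39600 nM in this assay. Compound 2 `CCc1ccccc1-n1nncc1CN1C(=O)C2(C(C#N)=C(N)Oc3c(N)cc4nc5ccccc5nc4c32)c2ccccc21` gives 24600 nM in this assay. The two numbers lie within the scatter of each other, so compound 2 does not stand apart from compound 1 on the values at hand; the two also differ in more than one place, so no single structural step can be read from them.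

Compound 3 `COc1ccc(-n2nncc2CN2C(=O)C3(C(C#N)=C(N)Oc4c(N)cc5nc6ccccc6nc5c43)c3ccccc32)cc1` is the next candidate. It differs from compound 2 in one place: 4-methoxyphenyl in place of 2-ethylphenyl on an aromatic nitrogen. Among the compounds with values here, no measured pair isolates this change, so there is no direct precedent for its size or direction. With two measurements only, and both within the scatter of each other, the working assumption is that this change produces no step beyond the scatter in this assay.

For compound 3 the expected value in this assay is 25000 nM, with a range from 10000 nM to 60000 nM. The estimate means a step of a 1.0-fold higher number from compound 2 to compound 3 (0.01 log units; within the scatter), which is expected to stay within the scatter, with either direction possible.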

Compound 3, half-maximal inhibitory concentration: > 50000 nM
Compound 3: no number, only a limit; the forecaster's own chance of this, stated with the estimate: 10%; middle value at least 2.0-fold (0.30 log units) from the limit.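

Compound 3 gives a limit of the assay rather than a number in this assay: the limit of > 50000 nM in this assay, at which 1 of the 3 values shown sits. Within the data shown here, this is the first step that can be read at a single place: 4-methoxyphenyl in place of 2-ethylphenyl on the aromatic nitrogen gives an at least 2.0-fold higher number from compound 2 to compound 3 (0.30 log units; that floor lies within the scatter), and since only a floor is known, the true size of the step stays unknown and this floor alone does not establish a real loss, though the swap shows no gain at this position. The swap changes the substituent and its place on the phenyl ring together, so the step cannot be assigned to either one alone.

Still open, as far as these compounds go, is whether any group on this phenyl ring, such as an amine or a carboxylic acid, would bring a number clearly lower than that of compound 2. The pair of compound 1 and compound 2 differs in more than one place, so the contribution of the rest of the core cannot be read from the compounds shown.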